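Carboxybenzyl to trifluoromethylbenzyl: expected tolerance of compound 4

The source may report more compounds than this note shows. Statements on the series, on what has been measured and on what is new or still open speak of the compounds shown alone.

Compound 3 `Cc1cc(/C=C2\SC(=S)N(Cc3cccc(C(=O)O)c3)C2=O)c(C)n1-c1ccc(O)c(C(=O)O)c1` carries a 3-carboxybenzyl group on the ring nitrogen of the shared core. In an ADME assay on MT2 cells (Homo sapiens) for cytotoxicity, read by XTT assay, with a stated time of 4 days (a higher number here means that more compound is tolerated, a lower number that less compound is tolerated), compound 3 gives only the limit > 100000 nM, which is a limit of the assay rather than a number. Its place is therefore read from its neighbours. Compound 1 `Cc1cc(/C=C2\SC(=S)N(Cc3ccccc3)C2=O)c(C)n1-c1ccc(O)c(C(=O)O)c1`, with an unsubstituted benzyl, gives 159000 nM in this assay. Compound 2 `COC(=O)c1cccc(CN2C(=O)/C(=C/c3cc(C)n(-c4ccc(O)c(C(=O)O)c4)c3C)SC2=S)c1`, with methoxycarbonyl on the benzyl ring, gives 38500 nM in this assay. The step of a 4.1-fold lower number from compound 1 to compound 2 (0.62 log units; beyond the scatter) lowers the tolerated concentration, and an at least 2.5-fold higher number from compound 2 to compound 3 (0.41 log units; beyond the scatter) brings it back up; the direct step that the limit leaves unreadable from compound 1 to compound 3 cannot be sized because of the limit of > 100000 nM in this assay, at which 1 of the 3 values shown sits.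

Compound 4 `Cc1cc(/C=C2\SC(=S)N(Cc3ccccc3C(F)(F)F)C2=O)c(C)n1-c1ccc(O)c(C(=O)O)c1` is the next member. The change is 2-(trifluoromethyl)phenyl in place of 3-carboxyphenyl on a saturated chain carbon bound to an amide-type nitrogen in a ring. Going by the values given here, no measured step involves a trifluoromethyl group, so the only anchor is compound 1 at 159000 nM and the observation that a carboxy on the benzyl ring did not lower tolerance. Compound 4 is therefore expected near 90000 nM, within 30000 nM to 200000 nM. The implied step an at least 1.1-fold lower number from compound 3 to compound 4 (0.04 log units; that floor lies within the scatter) is expected to be small and possibly unreadable against the limit.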

Compound 4, half-maximal cytotoxic concentration: 28800 nM
Estimate against measurement, compound 4: 3.1-fold (0.49 log units) above; measured number below the stated range.
By their numbers in this assay, from the lowest: compounds 4 and 2 (each within the scatter of the next); then compound 1.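

In this assay, trifluoromethyl on the benzyl ring lowers the tolerated concentration, with a 5.5-fold lower number from compound 1 to compound 4 (0.74 log units; beyond the scatter), so a second substituent on this ring now gives a drop from the unsubstituted benzyl of compound 1. Compound 2 and compound 4 do not separate, with a 1.3-fold lower number from compound 2 to compound 4 (0.13 log units; within the scatter), so methoxycarbonyl and trifluoromethyl lead to the same level here, and among the substituted benzyl groups shown only the 3-carboxybenzyl of compound 3 stands apart from them. The change from 3-carboxyphenyl to 2-(trifluoromethyl)phenyl gives an at least 3.4-fold lower number from compound 3 to compound 4 (0.54 log units; beyond the scatter), and this step is only a floor, as compound 3 holds a limit and not a number: the limit of > 100000 nM in this assay, at which 1 of the 4 values shown sits.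

The compounds shown leave open whether the lower tolerance follows the group or its place on the benzyl ring, as trifluoromethyl and methoxycarbonyl each appear at one place only. An amine or a hydroxy group on the benzyl ring, or a longer chain in place of the benzyl carbon, would show whether the carboxylic acid alone keeps the number high.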